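The source may hold more compounds than are shown below. What is called first, only, known or untested is meant among the compounds shown, and "the series" means these compounds.

Measured so far in a functional assay on HCT-116 cells (Homo sapiens) for antiproliferative activity, read by CCK-8 assay, with a stated time of 72 h, tested at 2 uM; a lower number here means a weaker effect, a higher number a stronger effect of the compound at the concentration tested:
compound 1 `Nc1ccccc1NC(=O)c1ccc(Cn2cnc3c(Nc4ccccc4)nc(Cl)nc32)cc1`: 71.4%
compound 2 `Nc1ccccc1NC(=O)/C=C/c1ccc(Cn2cnc3c(Nc4cccc(OC(F)(F)F)c4)nc(Cl)nc32)cc1`: 2.8%

Compound 2 stands lowest of the two numbers in this assay; the nearest number, that of compound 1, lies well beyond the scatter above it. Among the compounds with values here, compound 1 and compound 2 differ in more than one place, so no single step can be read from their pair; their two values show only that the combination of changes lowers the read-out sharply.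

Compound 3 `Nc1ccccc1NC(=O)/C=C/c1ccc(Cn2cnc3c(Nc4ccccc4)nc(Cl)nc32)cc1` is not yet measured. It differs from compound 2 as follows: hydrogen in place of trifluoromethoxy on an aromatic carbon. The resulting compound shares the anilino group of compound 1 and the propenamide linker of compound 2, so it sits between the two measured structures.

Within the data shown here, with no measured step of this kind, the direction is expected to be upward from compound 2, of uncertain size, since compound 1 gives 71.4% with the anilino group present; compound 3 is estimated at 35%, with a range of 5% to 72%. The expected step from compound 2 to compound 3 is a number 32.2 percentage points higher from compound 2 to compound 3 (beyond the scatter).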

Compound 3, a percentage reported as inhibition, at one concentration (the size of the read-out at that concentration, not a potency): 7.75%
The estimate for compound 3 lay 27.3 percentage points above the measured number; the measured number falls inside the stated range.
By their numbers in this assay, from the lowest: compounds 2 and 3 (each within the scatter of the next); then compound 1.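

In this assay the step for hydrogen in place of trifluoromethoxy on the aromatic carbon is a number 5 percentage points higher from compound 2 to compound 3 (within the scatter) and so gives no separation between the two groups at this position while the ethenyl linker is present. The large change lies with the other difference, as 2-((2-aminophenyl)carbamoyl)ethenyl in place of (2-aminophenyl)carbamoyl gives a number 63.7 percentage points lower from compound 1 to compound 3 (beyond the scatter) on the unsubstituted anilino series, a single change that the pair of compound 1 and compound 2 could not isolate. Nothing available bears on the reason for either step.

Going by these compounds, whether trifluoromethoxy is equally without consequence on the directly attached carbamoyl series of compound 1 remains open. Also open, on these data alone, is how an amine or a carboxylic acid at this aromatic carbon, or a saturated two-carbon chain in place of the ethenyl linker, would read out.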